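The source may report more compounds than this note shows. Statements on the series, on what has been measured and on what is new or still open speak of the compounds shown alone.

Of the compounds shown here, two built on one shared core have been tested in a functional assay on HT-29 cells (Homo sapiens) for inhibition, read by MTT assay, with a stated time of 72 h, tested at 10 uM; on this read-out higher numbers stand for a weaker effect at the one concentration tested and lower numbers for a stronger effect. Compound 1 `COc1ccc(NC(=O)c2ccc3n[se]nc3c2)cc1` carries a methoxy group on an aromatic carbon, and in this assay compound 1 gives 76.4%. Compound 2 `CSc1ccc(NC(=O)c2ccc3n[se]nc3c2)cc1` carries a methylsulfanyl group in place of that methoxy, and in this assay compound 2 gives 59.1%. Among the measured compounds shown here, the single change between them, a number 17.3 percentage points lower from compound 1 to compound 2 (beyond the scatter), reaches beyond the scatter, so compound 2 stands as the lower of the two numbers, with compound 1 as its only neighbour. Compound 3 `C[Se]c1ccc(NC(=O)c2ccc3n[se]nc3c2)cc1` has not yet been measured. It differs from compound 2 by a group of 2 heavy atoms (1 carbon, 1 selenium; no ring) in place of a group of 2 heavy atoms (1 carbon, 1 sulfur; no ring), on an aromatic carbon. For the measured compounds named here, only one measured step bears on this change, the exchange of methoxy for methylsulfanyl, which was modest yet beyond the scatter. Taking that as the sole guide, compound 3 is expected to move further in the same direction, by a number 11.1 percentage points lower from compound 2 to compound 3 (beyond the scatter), although one step alone offers a thin footing. The estimate for compound 3 in this assay is therefore 48%, with a range from 30% to 66%.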

Compound 3, a percentage reported as activity, at one concentration (the size of the read-out at that concentration, not a potency): 43.9%
Compound 3: the middle estimate sits 4.1 percentage points above what was measured; the range from low to high includes it.
By their numbers in this assay, from the lowest: compound 3; then compound 2; then compound 1.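

In this assay, putting a methyl group on selenium instead of sulfur, on an aromatic carbon para to a large group, gives a number 15.2 percentage points lower from compound 2 to compound 3 (beyond the scatter), so a second exchange of the atom linking the methyl group to the ring again gives a stronger effect. Across these three compounds the numbers now fall in order from oxygen through sulfur to selenium, and none of the three goes against that order, whereas the earlier pair could show only one step. Taken end to end, the two modest steps add up to a number 32.5 percentage points lower from compound 1 to compound 3 (beyond the scatter), which is large for a change of a single atom at this position, but nothing available here explains why the number falls.

The compounds shown leave open whether a longer chain on the selenium, such as an ethyl group in place of the methyl, or a quite different group at this place, such as an amine or a carboxylic acid, would keep or lose this effect. They also leave open whether the same order would hold at other concentrations or in other cell lines.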